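A Single Methyl on the Hydroxypropyl Amide

The compounds below may be only part of what the source reports. "The series", "measured", "known", "first", "only" and "open" are said of these compounds alone.

In an ADME assay on microsomes from liver (Rattus norvegicus) for metabolic stability, using NADPH (a lower number here means slower removal, a higher number faster removal of the compound), compound 1 (`COC(=O)c1nc(-c2ccco2)c(C(F)(F)F)cc1N`) gives > 0.7 mL/min/kg as a limit of the assay and not a number. Among the compounds with values here, compound 2 (`CC(O)CNC(=O)c1nc(Br)c(C(F)(F)F)cc1N`) gives 0.0377 mL/min/kg as the only actual number so far, so it can be ranked against no other measured value. Compound 3 (`CC(C)(O)CNC(=O)c1nc(Br)c(C(F)(F)F)cc1N`) departs from compound 2 in one place (methyl in place of hydrogen on a saturated chain carbon bound to an oxygen on a saturated carbon and two saturated chain carbons), with methyl in place of hydrogen on a saturated chain carbon bound to an oxygen on a saturated carbon and two saturated chain carbons. This turns 2-hydroxypropyl into 2-hydroxy-2-methylpropyl. Within the data shown here, no measured pair shows this change. In this assay no step beyond the usual scatter is expected, in either direction. The expected step (a 1.1-fold lower number from compound 2 to compound 3 (0.03 log units; within the scatter)) is accordingly small. Compound 3 is estimated at 0.035 mL/min/kg with an expected range of 0.015 mL/min/kg to 0.08 mL/min/kg in this measurement.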

Compound 3, clearance: < 0.025 mL/min/kg
Compound 3: no number, only a limit; the forecaster's own chance of this, stated with the estimate: 10%; middle value at least 1.4-fold (0.14 log units) away from the limit.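

The methyl in place of hydrogen on the saturated chain carbon gives the series its first step that can be read in this assay, and that step is an at least 1.5-fold lower number from compound 2 to compound 3 (0.17 log units; that floor lies within the scatter). The value of compound 3 is a limit of the assay and not a number: the limit of < 0.025 mL/min/kg in this assay, at which 1 of the 3 values shown sits. As far as these compounds go, on this evidence compound 2 and compound 3 cannot be separated beyond the scatter, and the true size of the step remains unknown.

Compound 1 differs from compound 2 in more than one place, so it gives no reading on this change. Still open, from the compounds shown here alone, is how an amine in place of the hydroxyl on this chain carbon, or a longer chain such as 3-hydroxybutyl, would read in this assay.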